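Series notes: dropping the methylsulfonyl group on the way to compound 4

This account rests on a few compounds, and the source may have more. Where it says the series, first, only, none or still open, it means among the compounds named here.

Measured so far:
compound 1, `CS(=O)(=O)c1ccc(-c2cnc3[nH]cc(-c4nnc(-c5ccncc5)o4)c(=O)c3c2)cc1`: 6.65%
compound 2, `CS(=O)(=O)c1ccc(-c2cnc3[nH]cc(-c4nnc(-c5ccc(F)cc5)o4)c(=O)c3c2)cc1`: 11.1%
compound 3, `CS(=O)(=O)c1ccc(-c2cnc3[nH]cc(-c4nnc(-c5ccc(Cl)cc5)o4)c(=O)c3c2)cc1`: 11.6%

In a functional assay on HepG2 cells (Homo sapiens) for inhibition, read by MTT assay, with a stated time of 24 h, tested at 10 uM (a lower number here means less inhibition of growth, a higher number more inhibition of growth at the concentration tested), compound 3 gives the highest of the three numbers. Its nearest neighbour is compound 2 and its furthest is compound 1, yet the step of a number 0.5 percentage points higher from compound 2 to compound 3 (within the scatter) and the step of a number 5 percentage points higher from compound 1 to compound 3 (within the scatter) both sit within the scatter, so compound 3 cannot be called more active than either. The third step, a number 4.5 percentage points higher from compound 1 to compound 2 (within the scatter), is also within the scatter. All three measured steps alter the same aryl group and leave the rest of the shared core untouched.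

Compound 4, `O=c1c(-c2nnc(-c3ccc(Cl)cc3)o2)c[nH]c2ncc(-c3ccccc3)cc12`, differs from compound 3 in one place: hydrogen in place of methylsulfonyl on an aromatic carbon. Among the measured compounds shown here, no measured step touches this position, so nothing in the numbers so far speaks to it; the only guide is that every change tried stayed within the scatter.

Accordingly no step beyond the scatter is expected, a number 1.6 percentage points lower from compound 3 to compound 4 (within the scatter). Compound 4 is expected to give 10% in this assay, with an estimated range from 0% to 25%.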

Compound 4, percent growth inhibition at one concentration: 14.9%
Compound 4: the middle estimate sits 4.9 percentage points below what was measured; low and high end bracket the measured number.
By their numbers in this assay, from the lowest: compounds 1, 2, 3 and 4 (each within the scatter of the next).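

In this assay, among the compounds shown here, hydrogen in place of methylsulfonyl gives a number 3.3 percentage points higher from compound 3 to compound 4 (within the scatter), the first reading at this position, which the earlier aryl changes left untouched. Cutting 4-(methylsulfonyl)phenyl back to phenyl removes 4 heavy atoms and 2 hydrogen-bond acceptors, yet compound 4 cannot be told apart from compound 3, so methylsulfonyl is not needed to hold the growth inhibition seen with compound 3 at the concentration tested. No supporting data bear on the reason for this result.

Going by these compounds, it remains open whether any group on this aromatic carbon, such as an amine, a carboxylic acid or a methoxy group, would give a step beyond the scatter. On these data alone, it is also open whether the same change reads alike with 4-fluorophenyl or pyridin-4-yl in place of 4-chlorophenyl.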